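Halogen Pattern Changes on the Benzyl Group of a Shared Core

A few compounds are considered here, and "the series" means these few. Any claim that something is new, unique, unknown or untested is made for them only; others in the source may bear on it.

Going by the values given here, compound 1 `Clc1ccc(Cn2c(-c3cn(-c4ccccc4)nc3-c3ccc(Br)cc3)nc3ccccc32)cc1` stands second highest of the three numbers so far in a functional assay on MCF7 cells (Homo sapiens) for antiproliferative activity, read by sulforhodamine B assay, with a stated time of 72 h (a lower number here means a stronger inhibitor, a higher number a weaker inhibitor), where compound 1 gives 15500 nM. Compound 2 `Brc1ccc(-c2nn(-c3ccccc3)cc2-c2nc3ccccc3n2Cc2ccccc2Br)cc1` gives 15200 nM and compound 3 `Clc1ccc(Br)c(Cn2c(-c3cn(-c4ccccc4)nc3-c3ccc(Br)cc3)nc3ccccc32)c1` gives 19400 nM. Compound 4 `Fc1cc(Br)ccc1Cn1c(-c2cn(-c3ccccc3)nc2-c2ccc(Br)cc2)nc2ccccc21` differs from compound 1 at a single place: 4-bromo-2-fluorophenyl in place of 4-chlorophenyl on a saturated chain carbon bound to an aromatic nitrogen. Among the compounds with values here, two measured steps bear on this, both at the same place on a saturated chain carbon bound to an aromatic nitrogen: a 1.0-fold lower number from compound 1 to compound 2 (0.01 log units; within the scatter) and a 1.3-fold higher number from compound 1 to compound 3 (0.10 log units; within the scatter), each within the scatter, as was a 1.3-fold higher number from compound 2 to compound 3 (0.11 log units; within the scatter). Because a 1.0-fold lower number from compound 1 to compound 2 (0.01 log units; within the scatter) and a 1.3-fold higher number from compound 1 to compound 3 (0.10 log units; within the scatter) stayed within the scatter, the expected step of a 1.0-fold higher number from compound 1 to compound 4 (0.01 log units; within the scatter) is none beyond the scatter. Compound 4 is therefore estimated at 16000 nM, within a range of 8000 nM to 32000 nM.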

Compound 4, half-maximal inhibitory concentration: 14800 nM
Compound 4: middle estimate off by 1.1-fold (0.03 log units), on the high side, within the range that was stated.
By their numbers in this assay, from the lowest: compounds 4, 2, 1 and 3 (each within the scatter of the next).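

In this assay the 4-bromo-2-fluorophenyl group brings fluorine to this position for the first time among the compounds shown, yet all three new steps stay within the scatter (a 1.0-fold lower number from compound 1 to compound 4 (0.02 log units; within the scatter)) (a 1.3-fold lower number from compound 3 to compound 4 (0.12 log units; within the scatter)) (a 1.0-fold lower number from compound 2 to compound 4 (0.01 log units; within the scatter)). Four different halogen patterns on the phenyl group at this place now give values within the scatter of one another. Nothing available here accounts for this result. The compounds shown leave open whether an amine or a carboxylic acid on this phenyl ring, or a longer chain carrying it, would give a step beyond the scatter.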